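Side-chain ether placement: outlook for compound 4

This account rests on a few compounds, and the source may have more. Where it says the series, first, only, none or still open, it means among the compounds named here.

Measured so far in this series:
compound 1, `CC(C(=O)NCc1ccc(C(C)(C)C)nc1N1CCCC1)c1ccc(NS(C)(=O)=O)c(F)c1`, 1.2 nM
compound 2, `CC(C)COc1nc(C(C)(C)C)ccc1CNC(=O)C(C)c1ccc(NS(C)(=O)=O)c(F)c1`, 0.6 nM
compound 3, `CCOCCOc1nc(C(C)(C)C)ccc1CNC(=O)C(C)c1ccc(NS(C)(=O)=O)c(F)c1`, 23.9 nM

All three were read in an assay on cells for antagonist activity at transient receptor potential cation channel subfamily V member 1 (Homo sapiens), read by FLIPR and calcium flux, with a stated time of 6 min; a lower number here means a stronger inhibitor, a higher number a weaker inhibitor. Compound 3 gives the highest number of the three: the step of a 20-fold higher number from compound 1 to compound 3 (1.30 log units; beyond the scatter) and the step of a 40-fold higher number from compound 2 to compound 3 (1.60 log units; beyond the scatter) both lie well beyond the scatter, whereas the step of a 2.0-fold lower number from compound 1 to compound 2 (0.30 log units; within the scatter) does not.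

Compound 4 is `COCCCOc1nc(C(C)(C)C)ccc1CNC(=O)C(C)c1ccc(NS(C)(=O)=O)c(F)c1`. It differs from compound 3 by methoxymethyl in place of ethoxy on a saturated chain carbon, two bonds along the chain from an oxygen on an aromatic ring.

Of the measured steps, only a 40-fold higher number from compound 2 to compound 3 (1.60 log units; beyond the scatter) touches the same chain, and it was large; it introduced the chain ether oxygen rather than moving it. The steps of a 20-fold higher number from compound 1 to compound 3 (1.30 log units; beyond the scatter) and a 2.0-fold lower number from compound 1 to compound 2 (0.30 log units; within the scatter) exchange the whole group on the aromatic carbon and bear on compound 4 only indirectly. Within the data shown here, no measured pair shifts the ether oxygen along the chain, so there is no direct precedent for this change. With the same atoms kept and only their order changed, compound 4 is expected to stay near compound 3 in this assay, with a step of a 1.6-fold lower number from compound 3 to compound 4 (0.20 log units; within the scatter) that is expected to fall within the scatter.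

Compound 4 is therefore estimated at 15 nM, with a range from 4 nM to 60 nM.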

Compound 4, inhibition constant: 5.6 nM
For compound 4 the middle estimate is 2.7-fold (0.43 log units) above the measured one; the range from low to high includes it.
By their numbers in this assay, from the lowest: compounds 2 and 1 (each within the scatter of the next); then compound 4; then compound 3.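

Working notes on the chain ether. In this assay, reordering the same atoms from 2-ethoxyethoxy to 3-methoxypropoxy is not a neutral change: the result is a 4.3-fold lower number from compound 3 to compound 4 (0.63 log units; beyond the scatter), so the arrangement of the chain alone separates these two compounds beyond the scatter. The chain carrying the ether oxygen still falls short of the two groups without one, with a 9.3-fold higher number from compound 2 to compound 4 (0.97 log units; beyond the scatter) against isobutoxy and a 4.7-fold higher number from compound 1 to compound 4 (0.67 log units; beyond the scatter) against pyrrolidin-1-yl, so the reordering recovers only part of the larger loss seen in a 40-fold higher number from compound 2 to compound 3 (1.60 log units; beyond the scatter). No supporting data are available to explain why this reordering changes the number in this assay.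

A single pair cannot show whether the step follows the place of the chain oxygen or the length of the group at the end of the chain, since the two change together here. Also unresolved is how this assay would read for a longer chain such as 4-methoxybutoxy, for an unbranched butoxy chain with no ether oxygen, or for a terminal hydroxyl in place of the methoxy group.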